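Compound 3 to compound 4: a chain change

This account rests on a few compounds, and the source may have more. Where it says the series, first, only, none or still open, it means among the compounds named here.

Measured in an ADME assay on microsomes from liver (Homo sapiens) for metabolic stability, using NADPH, with a stated time of 60 min, in the presence of a further agent that is not named here; on this read-out higher numbers stand for fast clearance and lower numbers for slow clearance (each value is a limit):
- compound 1 `O=C(O)COc1ccc([C@H]2CC[C@]3(CC2)OOC2(O3)C3CC4CC2CC(C3)C4O)cc1`: < 7 mL.min-1.g-1
- compound 2 `O=C(O)COc1ccc([C@H]2CC[C@]3(CC2)OOC2(O3)C3CC4CC(C3)CC2C4)cc1Cl`: < 7 mL.min-1.g-1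
- compound 3 `O=C(O)CNC(=O)COc1ccc([C@H]2CC[C@]3(CC2)OOC2(O3)C3CC4CC(C3)CC2C4)cc1`: < 7 mL.min-1.g-1

Compound 3 gives < 7 mL.min-1.g-1 in this assay, and this is a limit, not a number. The same holds across the measured set: the limit of < 7 mL.min-1.g-1 in this assay, at which 3 of the 3 values shown sit. Going by the values given here, no two measured compounds differ in one place only, so no measured step bears on the change ahead.

Compound 4 `O=C(O)CCCCOc1ccc([C@H]2CC[C@]3(CC2)OOC2(O3)C3CC4CC(C3)CC2C4)cc1` remains to be measured. Its difference from compound 3 is as follows: 3-carboxypropyl in place of (carboxymethyl)carbamoyl on a saturated chain carbon bound to an oxygen on an aromatic ring. In words, 3-carboxypropyl stands in place of (carboxymethyl)carbamoyl on a saturated chain carbon bound to an oxygen on an aromatic ring.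

The expected size of the change in this assay is a number no lower from compound 3 to compound 4 (the limit leaves the size open), which is estimated to lie within the scatter, with no firm direction. This expectation rests on compound 3, whose < 7 mL.min-1.g-1 is a limit. A further limit would be no surprise. Compound 4 is estimated at 7 mL.min-1.g-1, with an expected range from 4 mL.min-1.g-1 to 15 mL.min-1.g-1.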

Compound 4, intrinsic clearance in microsomes: < 7 mL.min-1.g-1
Compound 4: no number, only a limit (the forecaster's own chance of this, stated with the estimate: 65%); the middle value sits exactly at the limit.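

In this assay compound 4 gives < 7 mL.min-1.g-1 as a limit. Compound 3 and compound 4 both stand as limits, so no step can be read between them. Still open is how the actual clearances of compound 1, compound 2, compound 3 and compound 4 compare, with every value shown at one limit: the limit of < 7 mL.min-1.g-1 in this assay, at which 4 of the 4 values shown sit.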